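The source may report more compounds than this note shows. Statements on the series, on what has been measured and on what is new or still open speak of the compounds shown alone.

Among the measured compounds shown here, in a functional assay on MGC-803 cells (Homo sapiens) for antiproliferative activity, read by MTT assay, with a stated time of 72 h (a lower number here means a stronger inhibitor, a higher number a weaker inhibitor), compound 2 `O=C(NO)c1ccc(NCc2nc(-c3ccccc3)nn2-c2ccccc2)cc1` gives 17700 nM, the highest of the two numbers so far. Compound 1 `O=C(NO)c1ccc(NCc2nc(-c3ccc(Cl)cc3)nn2-c2ccccc2)cc1` gives 5970 nM. Compound 3 `O=C(NO)c1ccc(NCc2nc(-c3ccccc3Cl)nn2-c2ccccc2)cc1` follows from compound 2 by chloro in place of hydrogen on an aromatic carbon, ortho to a large group. For the measured compounds named here, the only measured step bearing on this is a 3.0-fold higher number from compound 1 to compound 2 (0.47 log units; beyond the scatter), which removes a chloro standing elsewhere on the ring. A modest move to a lower number is therefore expected in this assay, and with less certainty, since the place differs. The expected change is a 1.9-fold lower number from compound 2 to compound 3 (0.27 log units; within the scatter). For compound 3 the estimated value is 9500 nM, with an expected range of 4000 nM to 22000 nM.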

Compound 3, half-maximal inhibitory concentration: > 20000 nM
Compound 3 gave a limit, no number; the forecaster's own chance of this, stated with the estimate: 3%; middle value at least 2.1-fold (0.32 log units) away from the limit.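

Chloro ortho to a large group brings no lower number in this assay: the result is an at least 1.1-fold higher number from compound 2 to compound 3 (0.05 log units; that floor lies within the scatter) and gives no order between the two compounds. The place of the chloro counts, as 2-chlorophenyl in place of 4-chlorophenyl gives an at least 3.3-fold higher number from compound 1 to compound 3 (0.52 log units; beyond the scatter) and the lower number stays with compound 1 alone. The reading for compound 3 is a limit, not a number: the limit of > 20000 nM in this assay, at which 1 of the 3 values shown sits.

Going by these compounds, how far compound 3 lies past that limit stays open. So does whether fluoro, methoxy or an amine in the same place would read like chloro.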